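A Side-Chain Swap Starting From an Assay Limit

The source may report more compounds than this note shows. Statements on the series, on what has been measured and on what is new or still open speak of the compounds shown alone.

Of the compounds shown here, three have been tested so far in a functional assay on FaDu cells (Homo sapiens) for cytotoxicity, read by MTT assay, with a stated time of 72 h; on this read-out higher numbers stand for lower toxicity in this test and lower numbers for higher toxicity in this test. Compound 1 (`COc1ccc(NC(=O)C(=O)c2cn(CC(C)(C)OC)c3ccccc23)cn1`) gives > 10000 nM here, which is a limit of the assay and not a number. Compound 2 (`COc1ccc(NC(=O)C(=O)c2cn(C(C)C)c3c(OC)cccc23)cn1`) gives > 10000 nM here, which is also a limit. Going by the values given here, compound 3 (`CC(C)Oc1ccc(NC(=O)C(=O)c2cn(C(C)C)c3ccccc23)cn1`) gives 408 nM and is the only one with a true number. Compound 1 therefore offers only a boundary as a starting point.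

Compound 4 (`COCC(C)n1cc(C(=O)C(=O)Nc2ccc(OC)nc2)c2ccccc21`) differs from compound 1 in one place, on an aromatic nitrogen of a five-membered aromatic ring: 1-(methoxymethyl)ethyl stands in place of 2-methoxy-2-methylpropyl (1-(methoxymethyl)ethyl in place of 2-methoxy-2-methylpropyl on an aromatic nitrogen). The rest of the structure is unchanged. Among the compounds with values here, no measured pair of compounds shows what a swap of this kind does.

The best guide is the limit of > 10000 nM in this assay, at which 2 of the 3 values shown sit, in the results so far, although compound 3 stands apart from that with 408 nM as its reading. The estimated size of a number no higher from compound 1 to compound 4 (the limit leaves the size open) stays within the usual scatter of repeated measurements, with no clear direction expected. For compound 4 the expected value is 10000 nM with an estimated range from 3000 nM to 20000 nM in this assay and a report of only the limit is quite likely.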

Compound 4, concentration lethal to 50% of the cells: 12 nM
Compound 4: middle estimate off by 830-fold (2.92 log units), on the high side; measured number outside the range, below it.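

The swap of 2-methoxy-2-methylpropyl for 1-(methoxymethyl)ethyl on the aromatic nitrogen gives an at least 830-fold lower number from compound 1 to compound 4 (2.92 log units; beyond the scatter) in this assay, so this position can shift the reading strongly towards higher toxicity in this test. The two side chains have much in common: neither has a ring or a net charge, each has 0 hydrogen-bond donors and 1 hydrogen-bond acceptor, and they differ only slightly in size, with 6 heavy atoms leaving and 5 entering, so even a small change in this side chain can go with a large step. The reading of compound 1, > 10000 nM, is a limit and not a number, so the step has a known minimum but no known full size.

The compounds shown leave open whether the oxygen in the side chain is needed, and what an amine or a carboxylic acid at the end of a chain on this nitrogen would do to the reading. They give no cause for the step, and they offer few exact numbers to compare, since the limit remains common in this set: the limit of > 10000 nM in this assay, at which 2 of the 4 values shown sit.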